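Swapping the Methoxyphenyl Arm for a Dimethylphenyl One

This account rests on a few compounds, and the source may have more. Where it says the series, first, only, none or still open, it means among the compounds named here.

Compound 3 `COc1ccccc1/C=C(\C(=O)c1ccc(Br)cc1)S(=O)(=O)Cc1ccc(F)cc1` has been measured in a functional assay on DU-145 cells (Homo sapiens) for inhibition, read by trypan blue exclusion, with a stated time of 96 h (on this read-out lower numbers stand for stronger inhibition of growth and higher numbers for weaker inhibition of growth), where compound 3 gives 25000 nM. Among the three compounds measured so far this is the highest number, so compound 3 is the weakest inhibitor of growth in the set. The nearest neighbour is compound 1 `O=C(/C(=C\c1ccc(F)cc1)S(=O)(=O)c1ccc(Br)cc1)c1ccc(Br)cc1`, which in this assay gives 4000 nM; furthest away is compound 2 `COc1ccccc1/C=C(\C(=O)c1ccc(Br)cc1)S(=O)(=O)c1ccc(C)cc1`, which gives 1000 nM. Going by the values given here, the only pair of compounds that differ in a single place gives the step of a 25-fold higher number from compound 2 to compound 3 (1.40 log units; beyond the scatter), a large shift tied to the group on the sulfonyl sulfur.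

Compound 4 `Cc1cc(C)cc(/C=C(\C(=O)c2ccc(Br)cc2)S(=O)(=O)Cc2ccc(F)cc2)c1` has not yet been measured. It differs from compound 3 in one place: 3,5-dimethylphenyl in place of 2-methoxyphenyl on a double-bonded chain carbon bound to a double-bonded chain carbon. Among the compounds with values here, this change sits on the double-bonded chain carbon, not on the sulfonyl sulfur, so the one measured step does not speak to it directly. Compounds 1 and 2 do carry different groups on that carbon, but they also differ on the sulfonyl sulfur, so their values cannot be split between the two places. With nothing pointing in either direction, no step beyond the scatter is expected, and the uncertainty is wide. Compound 4 is expected to give about 25000 nM, within a range from 8000 nM to 80000 nM. The expected step is therefore no change at the digits printed from compound 3 to compound 4 (within the scatter).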

Compound 4, concentration for 50% growth inhibition: 10000 nM
For compound 4 the middle estimate is 2.5-fold (0.40 log units) above the measured one; measured number inside the range.
By their numbers in this assay, from the lowest: compound 2; then compound 1; then compound 4; then compound 3.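

Going by these compounds alone, this is the only step here that changes the double-bonded chain carbon while the 4-fluorobenzyl group on the sulfonyl sulfur stays fixed. In this assay, replacing 2-methoxyphenyl with 3,5-dimethylphenyl gives a clean reading for that carbon (a 2.5-fold lower number from compound 3 to compound 4 (0.40 log units; beyond the scatter)), so the group there does affect the number, although this modest step is much smaller than the one tied to the sulfonyl sulfur (a 25-fold higher number from compound 2 to compound 3 (1.40 log units; beyond the scatter)). No supporting measurement explains the shift, so it remains an observation about this one pair of compounds.

As far as these compounds go, it remains open whether 3,5-dimethylphenyl would produce a similar step with the 4-methylphenyl group of compound 2 on the sulfonyl sulfur, since this change has been read only with 4-fluorobenzyl there. Also open, from the compounds shown here alone, is how the number would move if an arm carrying an amine or a carboxylic acid stood on the double-bonded chain carbon in place of 3,5-dimethylphenyl.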